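Replacing (5-Hydroxypentyl)amino with Bis(2-hydroxyethyl)amino

The source may hold more compounds than are shown below. What is called first, only, known or untested is meant among the compounds shown, and "the series" means these compounds.

Of the compounds shown here, three sharing one core have been measured in a functional assay on MOLT-4 cells (Homo sapiens) for inhibition, read by MTT assay, with a stated time of 4 days; a higher number here means a weaker inhibitor, a lower number a stronger inhibitor. Compound 1 `COc1cc(NC(C)CCCNC(=O)NNC(=O)NCCCCCO)c2ncccc2c1` gives only a limit, >= 250000 nM. Compound 3 `COc1cc(NC(C)CCCNC(=O)NNC(=O)NCCCC(C)Nc2cc(OC)cc3cccnc23)c2ncccc2c1` also gives only a limit, >= 250000 nM. Compound 1 therefore stands at the limit of >= 250000 nM in this assay, at which 2 of the 3 values shown sit. Compound 2 `COc1cc(NC(C)CCCNC(=O)NNC(=O)N(C)C(c2ccccc2)c2ccccc2)c2ncccc2c1` alone returns an actual number, 19000 nM.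

Compound 4 `COc1cc(NC(C)CCCNC(=O)NNC(=O)N(CCO)CCO)c2ncccc2c1` differs from compound 1 in one place: bis(2-hydroxyethyl)amino in place of (5-hydroxypentyl)amino on a carbonyl carbon. It carries bis(2-hydroxyethyl)amino in place of (5-hydroxypentyl)amino on a carbonyl carbon. For the measured compounds named here, no measured pair isolates this change, so any forecast remains tentative. The expected step is a number no higher from compound 1 to compound 4 (the limit leaves the size open), with no change beyond the scatter in this assay. For compound 4 the estimated value is 250000 nM, with an expected range of 100000 nM to 350000 nM.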

Compound 4, half-maximal inhibitory concentration: > 250000 nM
Compound 4: no number, only a limit; the forecaster's own chance of this, stated with the estimate: 80%; the middle value lies on the limit itself.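

Compound 1 and compound 4 each return only a limit, so the step between them cannot be read. The compounds shown leave open whether bis(2-hydroxyethyl)amino in place of (5-hydroxypentyl)amino on a carbonyl carbon changes inhibition at all.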